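Series notes: compound 2 to compound 3

The compounds below may be only part of what the source reports. "The series", "measured", "known", "first", "only" and "open" are said of these compounds alone.

In an ADME assay on Vero cells (Chlorocebus sabaeus) for cytotoxicity, read by MTT assay, with a stated time of 48 h (a higher number here means that more compound is tolerated, a lower number that less compound is tolerated), compound 1 `CC(C)(NC(=O)c1ccc([N+](=O)[O-])o1)c1ccc(C(F)(F)F)cc1` gives > 150000 nM, which is a limit. Compound 2 `CC(C)(NC(=O)c1ccc([N+](=O)[O-])o1)c1ccc(-c2ccc(Cl)cc2)cc1` gives > 140000 nM, also a limit, so its position is known only as a limit. Compound 3 `CC(C)(NC(=O)c1ccc([N+](=O)[O-])o1)c1ccc(COc2ccccc2Cl)cc1` carries (2-chlorophenoxy)methyl in place of 4-chlorophenyl on an aromatic carbon. Among the measured compounds shown here, the only measured step that bears on this change, a step that the two limits leave unreadable from compound 1 to compound 2, has no readable size, and it gives no direction. The estimated at least 1.1-fold lower number from compound 2 to compound 3 (0.06 log units; that floor lies within the scatter) is expected to stay within the scatter in this assay. For compound 3 the expected value is 120000 nM, with an estimated range of 40000 nM to 150000 nM.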

Compound 3, half-maximal cytotoxic concentration: 30000 nM
Compound 3: the middle estimate sits 4.0-fold (0.60 log units) above what was measured; the measured number lies below the stated range.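

In this assay compound 3 is the only one of the three with a value that is not a limit, and (2-chlorophenoxy)methyl at this position gives an at least 4.6-fold lower number from compound 2 to compound 3 (0.66 log units; beyond the scatter) and an at least 5.0-fold lower number from compound 1 to compound 3 (0.69 log units; beyond the scatter). The second step is only a floor, set by the limit of compound 1: the limit of > 150000 nM in this assay, at which 1 of the 3 values shown sits. The first is likewise a floor, set by the limit of compound 2: the limit of > 140000 nM in this assay, at which 1 of the 3 values shown sits.

The step between compound 1 and compound 2 cannot be read. From the compounds shown here alone, whether the chlorine, the oxygen or the added carbon matters stays open, and phenoxymethyl or benzyl at this position could separate them.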